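The source may report more compounds than this note shows. Statements on the series, on what has been measured and on what is new or still open speak of the compounds shown alone.

Measured compounds:
- compound 1 `Cc1ccc(Nc2nccc(-c3cnc4ccccc4c3)n2)cc1`, 46.3%
- compound 2 `Nc1nccc(-c2ccnc3ccccc23)n1`, 78.2%
- compound 3 `Cc1nc2ccccn2c1-c1ccnc(Nc2ccc(C(F)(F)F)cc2)n1`, 100%

In a functional assay on SK-LU-1 cells (Homo sapiens) for cytotoxicity, read by sulforhodamine B assay, with a stated time of 48 h, tested at 50 uM (on this read-out higher numbers stand for more inhibition at the one concentration tested (going by the name of the read-out) and lower numbers for less inhibition), compound 2 gives 78.2%, the second highest of the three numbers. Compound 3 gives 100%, a number beyond the scatter above it, and compound 1 gives 46.3%, a number beyond the scatter below it. The unmeasured compound 4 `Cc1ccc(Nc2nccc(-c3ccnc4ccccc34)n2)cc1` differs from compound 2 by 4-methylphenyl in place of hydrogen on a nitrogen on an aromatic ring. Among the compounds with values here, no step between measured compounds is available, and the two arylamino compounds stand on opposite sides of compound 2, so no direction for this change can be read from them. The step from compound 2 to compound 4 is therefore expected to be a number 3.2 percentage points lower from compound 2 to compound 4 (within the scatter), not beyond the scatter. Compound 4 is estimated at 75%, within 40% to 100%.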

Compound 4, a percentage reported as inhibition, at one concentration (the size of the read-out at that concentration, not a potency): 100%
For compound 4 the middle estimate is 25 percentage points below the measured one, within the range that was stated.
By their numbers in this assay, from the lowest: compound 1; then compound 2; then compounds 3 and 4 (each within the scatter of the next).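

In this assay the change of hydrogen to 4-methylphenyl on this nitrogen reads a number 21.8 percentage points higher from compound 2 to compound 4 (beyond the scatter) and so goes with more inhibition at the one concentration tested. Within the data shown here, the earlier compounds offered no pair differing in one place, so this is the first direct reading of any change at this position. Nothing measured here bears on why the number moves.

On these data alone, what stays open is whether another group on this nitrogen, such as plain phenyl, acetyl or a longer alkyl chain, would go the same way. This single step also leaves open whether the change would carry over to the cores of compound 1 and compound 3.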